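Nitro in place of trifluoromethyl on the pentyloxymethyl chain compounds

The source may report more compounds than this note shows. Statements on the series, on what has been measured and on what is new or still open speak of the compounds shown alone.

Measured so far in a physicochemical assay for solubility, read by HPLC, at pH 7.4; on this read-out higher numbers stand for higher solubility and lower numbers for lower solubility
- Compound 1 `CCCCCCCc1cc(=O)c2cc([N+](=O)[O-])ccc2[nH]1` gives < 5000 nM as a limit
- Compound 2 `CCCCCOCc1cc(=O)c2ccccc2[nH]1` gives > 200000 nM as a limit
- Compound 3 `CCCCCOCc1cc(=O)c2cc(C(F)(F)F)ccc2[nH]1` gives 15000 nM as a number

Within the data shown here, compound 3 gives 15000 nM as the only true number of the three. Compound 4 `CCCCCOCc1cc(=O)c2cc([N+](=O)[O-])ccc2[nH]1` keeps the chain and core of compound 3 and has one change, nitro in place of trifluoromethyl on an aromatic carbon in the counted terms.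

Among the measured compounds shown here, the one measured step involving trifluoromethyl is an at least 13-fold lower number from compound 2 to compound 3 (1.12 log units; beyond the scatter) and it is large. For the measured compounds named here, it replaces hydrogen, so it does not size trifluoromethyl against nitro, and no measured pair exchanges these two groups. Going by the values given here, compound 1 carries nitro on a different chain and gives the limit < 5000 nM as its only reading, which tilts the expectation slightly downward.

In this assay the expected step is a 1.3-fold lower number from compound 3 to compound 4 (0.10 log units; within the scatter) and so stays within the scatter. Compound 4 is expected at 12000 nM with a range from 5000 nM to 40000 nM as the estimate.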

Compound 4, solubility: 15000 nM
For compound 4 the middle estimate is 1.3-fold (0.10 log units) below the measured one; the range from low to high includes it.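

In this assay, among these compounds, there is no change at the digits printed from compound 3 to compound 4 (within the scatter), the first direct exchange of trifluoromethyl and nitro on this aromatic carbon, and it separates the two groups by nothing beyond the scatter. Nitro in place of hydrogen on the same carbon gives an at least 13-fold lower number from compound 2 to compound 4 (1.12 log units; beyond the scatter), and the size of this step is bounded only, since compound 2 reads as a limit: the limit of > 200000 nM in this assay, at which 1 of the 4 values shown sits. With nitro held on the shared core, pentyloxy in place of hexyl gives an at least 3.0-fold higher number from compound 1 to compound 4 (0.47 log units; beyond the scatter), so the chain matters as well, though compound 1 also reads as a limit: the limit of < 5000 nM in this assay, at which 1 of the 4 values shown sits.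

As far as these compounds go, the true distance from the unsubstituted compound 2 to compounds 3 and 4 remains open, as does whether nitro and trifluoromethyl still match on a chain other than pentyloxymethyl. Also open, from the compounds shown here alone, is where an amine or a carboxylic acid on this aromatic carbon would fall in this assay.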